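The compounds below may be only part of what the source reports. "The series", "measured", "known", "first", "only" and "open" are said of these compounds alone.

Measured so far:
compound 1, `COc1cc(C(C)=O)ccc1OCCCN1CCC(C(c2ccc(F)cc2)c2ccc(F)c(F)c2)CC1`, 1.26 nM in a functional assay (aorta) with Oryctolagus cuniculus as the target; a lower number here means tighter binding, a higher number weaker binding.
compound 2, `NC(=O)c1ccc(OCCCN2CCC(C(c3ccc(F)cc3)c3ccc(F)cc3)CC2)cc1`, 31.6 nM.

Compound 2 gives the higher of the two numbers; compound 1 sits far below it, and that gap lies beyond the scatter. Compound 3, `Fc1ccc(C(c2ccc(F)cc2)C2CCN(CCCOc3ccccc3)CC2)cc1`, is not yet measured. It differs from compound 2 in one place: hydrogen in place of carbamoyl on an aromatic carbon. Within the data shown here, no step between measured compounds reads on this change, so the expectation rests on the two values alone. Compound 1 shows that the aromatic ring at this end tolerates more than one kind of group with a strong number, but compound 1 and compound 2 differ in several places, so nothing can be said of the carbamoyl by itself. The step from compound 2 to compound 3 is expected to be small, at the edge of the scatter, and more likely towards a higher number. For compound 3 the estimate is 50 nM, within 10 nM to 250 nM, meaning a 1.6-fold higher number from compound 2 to compound 3 (0.20 log units; within the scatter).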

Compound 3, dissociation constant: 1.59 nM
Compound 3: middle estimate off by 31-fold (1.50 log units), on the high side, outside the stated range (below it).
By their numbers in this assay, from the lowest: compounds 1 and 3 (each within the scatter of the next); then compound 2.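

Hydrogen in place of carbamoyl on the aromatic carbon gives, in this assay, a 20-fold lower number from compound 2 to compound 3 (1.30 log units; beyond the scatter). The step shows that this place, para to a large group, needs no group at all for a low number: compound 3, with a bare phenoxy, gives 1.59 nM, so the higher number of compound 2 goes with the carbamoyl in this pair. Nothing at hand says why the carbamoyl carries such a cost.

Going by these compounds, it remains open whether this cost belongs to the carbamoyl alone or to any group at this place. A carboxylic acid, an amine or a nitrile on the same carbon of the core of compound 3 would separate these two readings.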